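Chain extension in a cytotoxicity screen

A few compounds are considered here, and "the series" means these few. Any claim that something is new, unique, unknown or untested is made for them only; others in the source may bear on it.

Compound 1 `CSc1nc(NCCCc2ccccc2)c2ccccc2n1` was tested in an ADME assay on BEAS-2B cells (Homo sapiens) for cytotoxicity, read by MTT assay, with a stated time of 72 h; a higher number here means a weaker inhibitor of growth, a lower number a stronger inhibitor of growth. In this assay compound 1 gives > 100000 nM, which is a limit of the assay rather than a number. Compound 2 `CCCCC[Se]c1nc(NCc2ccccc2)c2ccccc2n1` was tested in the same way. In this assay compound 2 gives > 100000 nM, again a limit and not a number. For the measured compounds named here, both values therefore sit at the limit of > 100000 nM in this assay, at which 2 of the 2 values shown sit, so compound 1 stands nowhere in particular among them: two limits give no ordering, and no step between measured compounds can be drawn.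

Compound 3 `CSc1nc(NCCCCc2ccccc2)c2ccccc2n1` has not been measured. It differs from compound 1 by benzyl in place of phenyl on a saturated chain carbon, three bonds along the chain from a nitrogen on an aromatic ring. No measured step sizes this change, and no other evidence bears on it. Because compound 1 sits at the limit of > 100000 nM in this assay, at which 2 of the 2 values shown sit, the step from compound 1 to compound 3 is expected to be none beyond the scatter a number no higher from compound 1 to compound 3 (the limit leaves the size open). Compound 3 is accordingly expected to come out at 100000 nM, within a range of 50000 nM to 200000 nM, and most probably as a limit once more.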

Compound 3, concentration for total growth inhibition: > 100000 nM
Compound 3: only a limit was reported (the forecaster's own chance of this, stated with the estimate: 80%); the middle value lies on the limit itself.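

In this assay compound 3 gives > 100000 nM, a limit of the assay and not a number. With compound 1 also at a limit, no step from compound 1 to compound 3 can be read: the limit of > 100000 nM in this assay, at which 3 of the 3 values shown sit.

The compounds shown leave open where their true values lie and whether benzyl in place of phenyl changes anything at all.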